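A few compounds are considered here, and "the series" means these few. Any claim that something is new, unique, unknown or untested is made for them only; others in the source may bear on it.

In a functional assay on HCT-116 cells (Homo sapiens), read by MTT assay, with a stated time of 72 h (on this read-out lower numbers stand for stronger inhibition and higher numbers for weaker inhibition), compound 1 (`Cc1ncnc2c1c(-c1cc3ccccc3o1)cn2[C@@H]1O[C@H](CO)[C@@H](O)[C@H]1O`) gives only a limit, > 20000 nM. Compound 2 (`Nc1nc(N)c2c(-c3ccco3)cn([C@@H]3O[C@H](CO)[C@@H](O)[C@H]3O)c2n1`) also gives only a limit, > 20000 nM. Compound 3 (`Cc1nc(N)c2c(-c3ccco3)cn([C@@H]3O[C@H](CO)[C@@H](O)[C@H]3O)c2n1`) likewise stands at a limit, > 20000 nM, and has no number of its own. All three share one reading: the limit of > 20000 nM in this assay, at which 3 of the 3 values shown sit. Going by the values given here, the only measured step, a step that the two limits leave unreadable from compound 2 to compound 3, is methyl in place of amino on an aromatic carbon, and it gives no size. Compound 4 (`Cc1nc(N)c2c(-c3ccoc3)cn([C@@H]3O[C@H](CO)[C@@H](O)[C@H]3O)c2n1`) differs from compound 3 by furan-3-yl in place of furan-2-yl on an aromatic carbon, furan-3-yl in place of furan-2-yl. Among the compounds with values here, no measured step concerns the furan, so no step beyond the scatter is expected. The estimated step is a number no higher from compound 3 to compound 4 (the limit leaves the size open). For compound 4 the expected value is 20000 nM, with an estimated range from 8000 nM to 50000 nM.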

Compound 4, half-maximal inhibitory concentration: > 20000 nM
Compound 4: a limit, no number; the forecaster's own chance of this, stated with the estimate: 85%; the middle value sits exactly at the limit.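

In this assay compound 4 gives only a limit (> 20000 nM), so no step can be read between compound 3 and compound 4. The compounds shown leave open how strongly any of them inhibits, and whether furan-3-yl and furan-2-yl differ at all: the limit of > 20000 nM in this assay, at which 4 of the 4 values shown sit.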